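Notes on the carbonyl-side aryl change toward compound 3

The source may hold more compounds than are shown below. What is called first, only, known or untested is meant among the compounds shown, and "the series" means these compounds.

Measured so far in a functional assay on HEK293 cells for agonist activity at probable G-protein coupled receptor 27 (Homo sapiens), read by a luciferase reporter and beta-arrestin recruitment, with a stated time of 10 min; on this read-out higher numbers stand for an effect only at larger amounts of compound and lower numbers for an effect already at smaller amounts:
compound 1 `Cc1cc(Cl)ccc1C(=O)Nc1ccc(S(=O)(=O)Nc2ccccc2)cc1` — 912 nM
compound 2 `O=C(Nc1ccc(S(=O)(=O)Nc2ccccc2)cc1)c1ccc(Cl)cc1Br` — 1020 nM

Compound 2 carries the highest of the two numbers measured in this assay; its nearest neighbour is compound 1, and the gap between them lies within the scatter, so no order between the two can be read.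

Compound 3 `COc1cc(Br)ccc1C(=O)Nc1ccc(S(=O)(=O)Nc2ccccc2)cc1` differs from compound 2 by 4-bromo-2-methoxyphenyl in place of 2-bromo-4-chlorophenyl on a carbonyl carbon. Within the data shown here, the one measured step on this ring, a 1.1-fold higher number from compound 1 to compound 2 (0.05 log units; within the scatter), stayed within the scatter. The change to compound 3 is broader than that step: a bromo takes the place of the chloro, a methoxy enters, and the ring now holds one hydrogen-bond acceptor. Among the measured compounds shown here, no measured step covers such a change, so the expectation rests on compound 2 alone.

Compound 3 is therefore expected to land close to compound 2, with a step of a 1.0-fold lower number from compound 2 to compound 3 (0.01 log units; within the scatter), not beyond the scatter in either direction. The estimate for compound 3 in this assay is 1000 nM, with a range from 350 nM to 3000 nM.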

Compound 3, half-maximal effective concentration: 1020 nM
Compound 3: middle estimate off by 1.0-fold (0.01 log units), on the low side, within the range that was stated.
By their numbers in this assay, from the lowest: compounds 1, 2 and 3 (each within the scatter of the next).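

In this assay the aryl group on this carbonyl carbon accepts a broader change than the earlier pair covered, with 4-bromo-2-methoxyphenyl replacing 2-bromo-4-chlorophenyl and 1 hydrogen-bond acceptor entering where the leaving group had none (no change at the digits printed from compound 2 to compound 3 (within the scatter)). Against the 4-chloro-2-methylphenyl group of compound 1 the reading is the same (a 1.1-fold higher number from compound 1 to compound 3 (0.05 log units; within the scatter)), so the three aryl groups cannot be ordered on this read-out. Nothing available explains this flat reading or ties it to any feature of these groups.

Still open, as far as these compounds go, is whether a carboxylic acid, an amine or a longer alkoxy chain on this ring would move the number beyond the scatter. Also open, from the compounds shown here alone, is whether the aromatic ring itself is needed, as a cyclohexyl group in its place would show.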